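The compounds below may be only part of what the source reports. "The series", "measured", "known", "first", "only" and "open" are said of these compounds alone.

- Compound 1 `C=C(Br)C(=O)Nc1ccc2c(c1)/C(=C/c1cccs1)C(=O)N2` gives 240 nM
- Compound 2 `C=C(Br)C(=O)Nc1ccc2c(c1)/C(=C\c1cccs1)C(=O)N2` gives 5500 nM

In a functional assay on HT-29 cells (Homo sapiens) for antiproliferative activity, read by MTT assay, with a stated time of 72 h (a higher number here means a weaker inhibitor, a lower number a stronger inhibitor), compound 1 holds the lower of the two numbers and so is the stronger inhibitor of the pair. Within the data shown here, the only measured step is large: a 23-fold higher number from compound 1 to compound 2 (1.36 log units; beyond the scatter) is what separates them, and it must be read alongside the fact that compounds 1 and 2 differ only in the configuration as drawn as the sole difference between the two structures. That step therefore concerns the drawn double bond and gives no direct measure of a change on the ring.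

Compound 3 `C=C(Br)C(=O)Nc1ccc2c(c1)/C(=C/c1sccc1C)C(=O)N2` keeps the configuration of compound 1 and differs in one place: methyl in place of hydrogen on an aromatic carbon (methyl in place of hydrogen on an aromatic carbon, turning thiophen-2-yl into 3-methylthiophen-2-yl). Among the measured compounds shown here, no measured step covers a change of this kind. The expectation therefore starts from compound 1 at 240 nM and not from compound 2 at 5500 nM as its reference point. In this assay the expected result is a 1.3-fold higher number from compound 1 to compound 3 (0.10 log units; within the scatter) and thus no shift beyond the scatter, though this estimate is uncertain. Compound 3 is estimated at 300 nM with an expected range from 100 nM to 1000 nM in this measurement.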

Compound 3, half-maximal inhibitory concentration: 1200 nM
Beside the measured number, compound 3's estimate is 4.0-fold (0.60 log units) below it, outside the stated range (above it).
By their numbers in this assay, from the lowest: compound 1; then compound 3; then compound 2.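

Turning thiophen-2-yl into 3-methylthiophen-2-yl gives a 5.0-fold higher number from compound 1 to compound 3 (0.70 log units; beyond the scatter) in this assay, so compound 3 is a weaker inhibitor than compound 1. Among these compounds, this is the first measured reading of a change on the ring itself: the earlier step concerned only the drawn double bond, whereas here the configuration stays as in compound 1 and a single methyl replaces a hydrogen on an aromatic carbon, next to the ring atom that bears a large group, and that alone moves the number beyond the scatter. Nothing given here explains why this methyl weakens the compound, so the step stands as an observation without a cause.

The compounds shown leave open whether the weakening belongs to methyl in particular or would also appear with another group at this position, such as a fluorine atom, a methoxy group or an ethyl chain. They also leave open whether a methyl on a different carbon of the ring, or the same methyl on the double-bond configuration of compound 2, would shift the number in the same direction or by a similar amount.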